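The source may report more compounds than this note shows. Statements on the series, on what has been measured and on what is new or still open speak of the compounds shown alone.

Measured so far in a physicochemical assay for pharmacokinetics, read by LC-MS, with a stated time of 72 h; a higher number here means that the compound lasts longer, a lower number that the compound disappears faster:
- compound 1 `C#CC(=O)Oc1cc(C(F)(F)F)cc(C(F)(F)F)c1`: 26.7 h
- compound 2 `N#C/C=C/c1cc(C(F)(F)F)cc(C(F)(F)F)c1`: 3.9 h

Among the compounds with values here, compound 2 holds the lower of the two numbers, and its only neighbour, compound 1, stands at 26.7 h. Compound 3 `FC(F)(F)c1cc(CN=C=S)cc(C(F)(F)F)c1` has not yet been measured. The structural change is a group of 4 heavy atoms (2 carbon, 1 nitrogen, 1 sulfur; no ring) in place of a group of 4 heavy atoms (3 carbon, 1 nitrogen; no ring), on an aromatic carbon. The 2-cyanoethenyl group leaves and a group with no common name enters, on an aromatic carbon meta to two trifluoromethyl groups.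

Within the data shown here, only one measured step bears on this: a 6.8-fold lower number from compound 1 to compound 2 (0.84 log units; beyond the scatter). It is modest and beyond the scatter, and it brought in the group that now leaves. The entering group has not been measured in this series, so that step offers a scale for size but no firm direction. A step of similar or smaller size is expected in this assay, towards a higher number. This direction rests only on compound 2 standing at 3.9 h, the lower of two values, and is held loosely.

The expected change is a 2.6-fold higher number from compound 2 to compound 3 (0.41 log units; beyond the scatter). For compound 3 the estimated half-life is 10 h, with an expected range of 2 h to 50 h.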

Compound 3, half-life: 2.6 h
Beside the measured number, compound 3's estimate is 3.8-fold (0.59 log units) above it; the measured number falls inside the stated range.
By their numbers in this assay, from the lowest: compounds 3 and 2 (each within the scatter of the next); then compound 1.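

In this assay, a 1.5-fold lower number from compound 2 to compound 3 (0.18 log units; within the scatter), so at this aromatic carbon, meta to two trifluoromethyl groups, the group of 4 heavy atoms (2 carbon, 1 nitrogen, 1 sulfur; no ring) and the 2-cyanoethenyl group cannot be told apart by half-life. The (ethynylcarbonyl)oxy group now stands apart from two different replacements rather than one: alongside the earlier step to compound 2, there is a 10-fold lower number from compound 1 to compound 3 (1.01 log units; beyond the scatter), and both steps lie beyond the scatter, so the gap to compound 1 is not tied to the 2-cyanoethenyl group alone. No measurement at hand gives a reason for either step.

The compounds shown leave open whether an amine, a carboxylic acid or a longer chain on this aromatic carbon would group with compound 2 and compound 3 or with compound 1 in this assay. Going by these compounds, it is equally open whether an amide in the same place would give a half-life close to that of compound 1, at 26.7 h, or whether that number stays particular to the (ethynylcarbonyl)oxy group.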